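This account rests on a few compounds, and the source may have more. Where it says the series, first, only, none or still open, it means among the compounds named here.

In a functional assay on HEK293 cells for antagonist activity at thromboxane A2 receptor (Homo sapiens), read by fluorescence and calcium flux (on this read-out higher numbers stand for weaker inhibition and lower numbers for stronger inhibition), compound 2 `CCCCCNC(=O)NS(=O)(=O)c1cc(C#N)ccc1Oc1ccc(C)cc1` gives 900 nM, the second highest of three numbers. Compound 1 `Cc1ccc(Oc2ccc(C#N)cc2S(=O)(=O)NC(=O)NC(C)(C)C)cc1` gives 750 nM, and compound 3 `CC(C)NC(=O)NS(=O)(=O)c1cc(C#N)ccc1Oc1ccc(Br)cc1` gives 9470 nM. For the measured compounds named here, the only measured step between single-point neighbours, a 1.2-fold higher number from compound 1 to compound 2 (0.08 log units; within the scatter), changes the group on the urea nitrogen and leaves the link between the two rings untouched. Compound 4 `CCCCCNC(=O)NS(=O)(=O)c1cc(C#N)ccc1Nc1ccccc1C` differs from compound 2 by (2-methylphenyl)amino in place of 4-methylphenoxy on an aromatic carbon. Going by the values given here, no measured step alters this part of the shared core, so nothing seen so far shows how large a change to expect, or in which direction. Compound 4 is therefore expected to stay close to its parent, estimated at 1500 nM with a range from 300 nM to 8000 nM. That estimate means an expected step of a 1.7-fold higher number from compound 2 to compound 4 (0.22 log units; within the scatter).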

Compound 4, half-maximal inhibitory concentration: 3190 nM
The estimate for compound 4 lay 2.1-fold (0.33 log units) below the measured number; measured number inside the range.
By their numbers in this assay, from the lowest: compounds 1 and 2 (each within the scatter of the next); then compound 4; then compound 3.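

For the compounds shown here, this is the first measured change at the aromatic carbon para to a cyano group, and in this assay the swap gives a 3.5-fold higher number from compound 2 to compound 4 (0.55 log units; beyond the scatter) and so modestly weaker inhibition. The position therefore responds to change, even though the entering group has the same heavy-atom count and its one aromatic ring, and adds a hydrogen-bond donor. No available evidence bears on this result.

The swap alters both the linking atom and the place of the methyl, and the compounds shown do not separate these two changes. A (4-methylphenyl)amino or 2-methylphenoxy group on this carbon would tell them apart.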